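Chloro-to-Methyl Swap on an Oxathiolane Nucleoside Core

The compounds below may be only part of what the source reports. "The series", "measured", "known", "first", "only" and "open" are said of these compounds alone.

The three measured compounds were tested in a functional assay on Vero cells (Chlorocebus sabaeus) for inhibition; on this read-out lower numbers stand for stronger inhibition and higher numbers for weaker inhibition. Compound 1 `O=c1[nH]c(=O)n([C@@H]2CS[C@@H](CO)O2)cc1Cl` carries a chloro group on its base. In this assay compound 1 reaches only a limit, > 100000 nM. Compound 2 `Cc1cn([C@@H]2CS[C@@H](CO)O2)c(=O)[nH]c1=O` differs from compound 1 by methyl in place of chloro on an aromatic carbon. In this assay compound 2 likewise reaches only a limit, > 100000 nM. The step from one to the other, a step that the two limits leave unreadable from compound 1 to compound 2, therefore cannot be sized, as both values sit at the limit of > 100000 nM in this assay, at which 2 of the 3 values shown sit.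

Among the compounds with values here, compound 3 `Nc1nc(=O)n([C@@H]2CS[C@@H](CO)O2)cc1Cl` is the one member of the set with a number: in this assay compound 3 gives 31200 nM. How the core of compound 3 differs from the core of compound 1 is not broken down here.

Compound 4 `Cc1cn([C@@H]2CS[C@@H](CO)O2)c(=O)nc1N` has not yet been measured. It differs from compound 3 by methyl in place of chloro on an aromatic carbon. This is the same kind of change as that from compound 1 to compound 2, though the surroundings are not identical: in compound 3 the changed carbon is ortho to an amino group, whereas in compound 1 it is ortho to a group of 1 heavy atom.

Since the step from compound 1 to compound 2 is unreadable and nothing else in the set bears on this change, compound 4 is expected to stay close to compound 3, with an estimated step of a 1.6-fold lower number from compound 3 to compound 4 (0.19 log units; within the scatter). The estimate for compound 4 is 20000 nM, expected to lie between 3000 nM and 100000 nM.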

Compound 4, half-maximal inhibitory concentration: > 100000 nM
Compound 4: a limit, no number (the forecaster's own chance of this, stated with the estimate: 30%); middle value at least 5.0-fold (0.69 log units) from the limit.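

On the core of compound 3, methyl in place of chloro on an aromatic carbon gives an at least 3.2-fold higher number from compound 3 to compound 4 (0.50 log units; beyond the scatter) in this assay, so on this core the chloro compound keeps a readable number and the methyl compound does not. From the compounds shown here alone, compound 4 is itself a limit, so the step has only a lower bound and its full size remains unknown: the limit of > 100000 nM in this assay, at which 3 of the 4 values shown sit. The matching step on the core of compound 1 cannot be read, as both of its ends are limits, so the result does not show whether the change behaves alike on the two cores, and one readable step sets no rule for carrying it from one core to another.

The compounds shown leave open whether another group on the same aromatic carbon, such as fluoro, bromo, ethyl or trifluoromethyl, would give a readable number on the core of compound 3 or would also end at the limit. They also leave open whether a longer chain in place of the hydroxymethyl group, such as hydroxyethyl, would change the number of compound 3 in this assay.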